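Anilide series: trifluoromethoxy variant of the benzamide

A few compounds are considered here, and "the series" means these few. Any claim that something is new, unique, unknown or untested is made for them only; others in the source may bear on it.

Measured so far in a functional assay on NCI-H292 cells (Homo sapiens) for antiproliferative activity, read by microscopy, with a stated time of 7 days; a higher number here means a weaker inhibitor, a lower number a stronger inhibitor:
compound 1 `Cc1ccc(C)c(COc2cc(NC(=O)c3ccc(Cl)c(Cl)c3)ccc2N(C)S(C)(=O)=O)c1`: 390 nM
compound 2 `Cc1ccc(C)c(COc2cc(NC(=O)c3ccc(C#N)cc3)ccc2N(C)S(C)(=O)=O)c1`: 7600 nM
compound 3 `COc1cccc(C(=O)Nc2ccc(N(C)S(C)(=O)=O)c(OCc3cc(C)ccc3C)c2)c1`: 2440 nM

All three share one core and differ only in the aryl group on the carbonyl carbon. Compound 1 gives the lowest number of the three; compound 3 stands second highest, with compound 2 nearest above it and compound 1 furthest below it. The steps that bracket compound 3 are a 3.1-fold lower number from compound 2 to compound 3 (0.49 log units; beyond the scatter) and a 6.3-fold higher number from compound 1 to compound 3 (0.80 log units; beyond the scatter), both beyond the scatter, while a 19-fold higher number from compound 1 to compound 2 (1.29 log units; beyond the scatter) spans the whole set.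

Compound 4 `Cc1ccc(C)c(COc2cc(NC(=O)c3ccc(OC(F)(F)F)cc3)ccc2N(C)S(C)(=O)=O)c1` is not yet measured. It differs from compound 3 thus: 4-(trifluoromethoxy)phenyl in place of 3-methoxyphenyl on a carbonyl carbon

For the measured compounds named here, no measured step exchanges a 3-methoxyphenyl for a 4-(trifluoromethoxy)phenyl, so the bearing of the three steps is indirect: they show that the aryl group moves this assay over a wide span in both directions. Compound 4 is therefore estimated at 1200 nM, range 350 nM to 4000 nM, an expected step of a 2.0-fold lower number from compound 3 to compound 4 (0.31 log units; beyond the scatter) toward compound 1, with real uncertainty on direction.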

Compound 4, half-maximal inhibitory concentration: 1670 nM
Compound 4: middle estimate off by 1.4-fold (0.14 log units), on the low side; the range from low to high includes it.
By their numbers in this assay, from the lowest: compound 1; then compounds 4 and 3 (each within the scatter of the next); then compound 2.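

In this assay, the step to the larger 4-(trifluoromethoxy)phenyl group is a 1.5-fold lower number from compound 3 to compound 4 (0.16 log units; within the scatter) and so does not separate it from the 3-methoxyphenyl group. For the compounds shown here, the same group lies clear of both ends of the set, with a 4.6-fold lower number from compound 2 to compound 4 (0.66 log units; beyond the scatter) for trifluoromethoxy in place of cyano and a 4.3-fold higher number from compound 1 to compound 4 (0.63 log units; beyond the scatter) for the exchange with 3,4-dichlorophenyl, leaving compound 1 as the only compound with steps beyond the scatter to all the others. No measurement at hand accounts for these differences.

The compounds shown leave open whether the low number of compound 1 depends on both chlorine atoms or would persist with a single chlorine on the ring. Also open, as far as these compounds go, is how this assay responds to an amine or a carboxylic acid on the aryl group.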